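Working notes: aryl exchange on the ring amine nitrogen

This account rests on a few compounds, and the source may have more. Where it says the series, first, only, none or still open, it means among the compounds named here.

Measured so far:
compound 1 `CC(C)N1CCN(Cc2csc(N)c2C(=O)c2ccc(Cl)cc2)CC1` — -1%
compound 2 `Nc1scc(CN2CCN(c3cc(Cl)cc(Cl)c3)CC2)c1C(=O)c1ccc(Cl)cc1` — -1%

In a functional assay on CHO cells with adenosine receptor A1 (Homo sapiens) as the target, read by cAMP accumulation and immunoassay, with a stated time of 6 min, tested at 0.01 uM (a lower number here means a stronger effect, a higher number a weaker effect of the compound at the concentration tested), compound 1 gives -1% and compound 2 gives -1%. For the measured compounds named here, the single measured step, no change at the digits printed from compound 1 to compound 2 (within the scatter), exchanged the group on the amine nitrogen in the ring and left the read-out where it was; both compounds sit at a level that cannot be told from no effect at the concentration tested. Compound 2 therefore stands level with compound 1, with no step beyond the scatter in either direction.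

Compound 3 `Nc1scc(CN2CCN(c3ccc(Cl)cc3F)CC2)c1C(=O)c1ccc(Cl)cc1` is the next variant at the same position: 4-chloro-2-fluorophenyl in place of 3,5-dichlorophenyl on an amine nitrogen in a ring. Going by the values given here, the only step that bears on this change is no change at the digits printed from compound 1 to compound 2 (within the scatter), since it also concerns the substituent on the ring amine nitrogen, and it was within the scatter despite a far larger exchange of group type. On that basis compound 3 is expected to show no step beyond the scatter, no change at the digits printed from compound 2 to compound 3 (within the scatter). The estimate for compound 3 in this assay is -1%, with an expected range from -12% to 10%; a further inactive point in a flat set of two is the likeliest outcome.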

Compound 3, a percentage reported as activity, at one concentration (the size of the read-out at that concentration, not a potency): -9.2%
Compound 3: the middle estimate sits 8.2 percentage points above what was measured, within the range that was stated.
By their numbers in this assay, from the lowest: compounds 3, 1 and 2 (each within the scatter of the next).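

Two further exchanges on the amine nitrogen in the ring now stay within the scatter in this assay: 4-chloro-2-fluorophenyl in place of 3,5-dichlorophenyl gives a number 8.2 percentage points lower from compound 2 to compound 3 (within the scatter) and 4-chloro-2-fluorophenyl in place of isopropyl gives a number 8.2 percentage points lower from compound 1 to compound 3 (within the scatter) at this position. The flat reading therefore extends beyond one exchange, covering a change in the halogens on the phenyl ring as well as a second comparison of an aryl group with isopropyl, and compounds 1, 2 and 3 cannot be ordered from these values. Nothing available explains this flat reading.

All three groups carry no hydrogen-bond donor or acceptor of their own where this is counted for the 3,5-dichlorophenyl and 4-chloro-2-fluorophenyl groups, so the compounds shown leave open whether a carboxylic acid, a primary amine or a longer chain ending in a hydroxyl group on the same nitrogen would move the read-out beyond the scatter. They also leave open whether replacing the 4-chlorophenyl group on the carbonyl with an unsubstituted phenyl would change the read-out, since that part of the core is the same throughout.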